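This account rests on a few compounds, and the source may have more. Where it says the series, first, only, none or still open, it means among the compounds named here.

Working notes on a small series sharing one core, read in a functional assay on MCF7 cells (Homo sapiens) for antiproliferative activity, read by MTT assay, with stated times of 24 h and 72 h; on this read-out lower numbers stand for stronger inhibition and higher numbers for weaker inhibition. Compound 1 `COc1cc(N2C(=O)[C@@H](Oc3ccccc3)[C@H]2c2ccc(Br)cc2)cc(OC)c1OC` gives 48000 nM, compound 2 `COc1cc(N2C(=O)[C@@H](Oc3ccccc3)[C@H]2c2ccc3ccccc3c2)cc(OC)c1OC` gives 282000 nM, and compound 3 `COc1cc(N2C(=O)[C@@H](Oc3ccccc3)[C@H]2c2ccc([N+](=O)[O-])cc2)cc(OC)c1OC` gives 63000 nM. Compound 3 therefore lies within the scatter of compound 1, and both sit clearly lower than compound 2, the highest number of the three.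

The next compound is compound 4 `COc1cc(N2C(=O)[C@@H](Oc3ccccc3)[C@H]2c2ccc(N=[N+]=[N-])cc2)cc(OC)c1OC`, which carries azido in place of nitro on an aromatic carbon, para to a large group: azido in place of nitro on an aromatic carbon. For the measured compounds named here, the closest precedent is a 1.3-fold higher number from compound 1 to compound 3 (0.12 log units; within the scatter), the only measured exchange of one group at this place, and it stays within the scatter. The larger steps, a 5.9-fold higher number from compound 1 to compound 2 (0.77 log units; beyond the scatter) and a 4.5-fold lower number from compound 2 to compound 3 (0.65 log units; beyond the scatter), both involve naphthalen-2-yl, which compound 4 does not carry, so they bear on this change only weakly. Going by the values given here, one precedent is thin evidence, and no measured compound yet carries azido. Even so, no step beyond the scatter is expected in this assay, and no direction can be favoured. The expected change is a 1.1-fold lower number from compound 3 to compound 4 (0.06 log units; within the scatter). For compound 4 the estimated value is 55000 nM, with an expected range from 22000 nM to 140000 nM.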

Compound 4, half-maximal inhibitory concentration: 23000 nM
For compound 4 the middle estimate is 2.4-fold (0.38 log units) above the measured one; measured number inside the range.
By their numbers in this assay, from the lowest: compound 4; then compounds 1 and 3 (each within the scatter of the next); then compound 2.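

In this assay the place para to a large group on the aromatic ring proves sensitive to the group it carries: azido gives a 2.7-fold lower number from compound 3 to compound 4 (0.44 log units; beyond the scatter) and a 2.1-fold lower number from compound 1 to compound 4 (0.32 log units; beyond the scatter) and so moves beyond the scatter, whereas the earlier exchange of bromo for nitro at this place stayed within it. Against naphthalen-2-yl the change is wider still, with a 12-fold lower number from compound 2 to compound 4 (1.09 log units; beyond the scatter) as the largest step in the series so far, and compound 4 now holds the lowest number of the four, its steps to all the others being beyond the scatter. No measurement at hand accounts for azido parting from nitro and bromo at this place.

On these data alone, whether the lower number is particular to azido or would also appear with another small group at this place, such as an amine, a nitrile or a carboxylic acid, remains open. Also open, as far as these compounds go, is how far the phenoxy group and the three methoxy groups bear on the number, as they stay the same in all four compounds.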